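A few compounds are considered here, and "the series" means these few. Any claim that something is new, unique, unknown or untested is made for them only; others in the source may bear on it.

Values in an ADME assay on liver (Homo sapiens) for metabolic stability, read by LC-MS, using microsomes and NADPH (on this read-out higher numbers stand for a more stable compound and lower numbers for a less stable compound), for the three measured compounds:
- compound 1 `COc1cc(CN(CC(C)C)C(CC(=O)O)c2ccc(Cl)cc2)ccc1OCCN1C(=O)CCC1=O` gives 80%
- compound 2 `COc1cc(CN(CC(C)C)C(CC(=O)O)c2ccc(Cl)cc2Cl)ccc1OCCN1C(=O)CCC1=O` gives 57%
- compound 3 `COc1cc(CN(CC(C)C)C(CC(=O)O)c2ccc(Cl)c(F)c2)ccc1OCCN1C(=O)CCC1=O` gives 76%

Compound 3 stands near the top of this small set, with a number 4 percentage points lower from compound 1 to compound 3 (within the scatter) on one side and a number 19 percentage points higher from compound 2 to compound 3 (beyond the scatter) on the other.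

Compound 4 `Cc1cc(CN(CC(C)C)C(CC(=O)O)c2ccc(Cl)c(F)c2)ccc1OCCN1C(=O)CCC1=O` keeps everything in compound 3 except for one change: it has methyl in place of methoxy on an aromatic carbon, ortho to a 2-(2,5-dioxopyrrolidin-1-yl)ethoxy group methyl in place of methoxy on an aromatic carbon in the core.

For the measured compounds named here, no measured step touches the methoxy, so the data offer no direct precedent and no direction for this change. The three steps concern only chloro and fluoro on the other aromatic ring. Going by the values given here, they show that one small replacement can leave the read-out unmoved, as in a number 4 percentage points lower from compound 1 to compound 3 (within the scatter) or can shift it modestly, as in a number 23 percentage points lower from compound 1 to compound 2 (beyond the scatter) and that is the only guide to size.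

The expected outcome is therefore a number 4 percentage points lower from compound 3 to compound 4 (within the scatter) and a larger step in either direction remains possible. In this assay compound 4 is expected at 72% with an estimated range from 55% to 87% around that middle.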

Compound 4, percent of the compound remaining: 63%
Compound 4: middle estimate off by 9 percentage points, on the high side; measured number inside the range.
By their numbers in this assay, from the lowest: compounds 2 and 4 (each within the scatter of the next); then compounds 3 and 1 (each within the scatter of the next).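

For the compounds shown here, the aromatic carbon ortho to a 2-(2,5-dioxopyrrolidin-1-yl)ethoxy group, untouched in the earlier compounds, proves able to move the read-out in this assay. Methyl in place of methoxy gives a number 13 percentage points lower from compound 3 to compound 4 (beyond the scatter) and so shows that the chloro and fluoro changes on the other aromatic ring are not the only single replacements to produce a step beyond the scatter. The change removes the methoxy oxygen and the one hydrogen-bond acceptor counted for that group, but nothing in the data explains why the number falls.

On these data alone, it remains open whether the step follows from losing the oxygen or from bringing in the methyl, and a hydroxyl group, an ethoxy group or a plain hydrogen on this carbon would help separate the two. Going by these compounds alone, it is also open whether the same replacement gives a similar step when the other aromatic ring is the one carried by compound 1 or compound 2.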